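Benzyl for phenyl at two different five-membered rings

The compounds below may be only part of what the source reports. "The series", "measured", "known", "first", "only" and "open" are said of these compounds alone.

Measured so far in a functional assay on the whole organism (plasma, strain Wistar) with Rattus norvegicus as the target, with a stated time of 15 days, at a dose of 30 mg/kg by the oral route; on this read-out higher numbers stand for a stronger effect at the one dose given and lower numbers for a weaker effect:
compound 1 `O=C1NC(=O)/C(=C/c2ccc(OCCSc3nnc(-c4ccccc4)[nH]3)cc2)S1` gives 14.7%
compound 2 `O=C1NC(=O)/C(=C/c2ccc(OCCSc3nnc(Cc4ccccc4)[nH]3)cc2)S1` gives 28.5%
compound 3 `O=C1NC(=O)/C(=C/c2ccc(OCCSc3nnc(-c4ccccc4)o3)cc2)S1` gives 16.1%

Compound 2 differs from compound 1 by benzyl in place of phenyl on an aromatic carbon. That change produced a number 13.8 percentage points higher from compound 1 to compound 2 (beyond the scatter). Compound 1 and compound 3 have different cores; the difference between the two cores is not broken down here, and their two values lie within the scatter of each other, so nothing is read from that pair. Compound 4 `O=C1NC(=O)/C(=C/c2ccc(OCCSc3nnc(Cc4ccccc4)o3)cc2)S1` has not yet been measured; it differs from compound 3 by benzyl in place of phenyl on an aromatic carbon. Going by the values given here, this is the same kind of change as the one from compound 1 to compound 2, not the same: in compound 1 the place is on a five-membered aromatic ring with 3 nitrogen, between two ring nitrogen atoms, while in compound 3 the place is on a five-membered aromatic ring with 2 nitrogen and 1 oxygen, next to the ring nitrogen and next to the ring oxygen. Among the compounds with values here, the expected step is a number 12.9 percentage points higher from compound 3 to compound 4 (beyond the scatter), because a number 13.8 percentage points higher from compound 1 to compound 2 (beyond the scatter) is the only measured instance of this kind of change, and the ring difference adds uncertainty. Compound 4 is therefore estimated at 29%, within a range from 16% to 42%.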

Compound 4, a percentage reported as activity, at one dose (the size of the read-out at that dose, not a potency): 19.1%
For compound 4 the middle estimate is 9.9 percentage points above the measured one; the range from low to high includes it.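

In this assay, benzyl in place of phenyl on the core of compound 3 gives a number 3 percentage points higher from compound 3 to compound 4 (within the scatter), so on this core the change has no effect that can be told from the scatter. Set beside the step on the core of compound 1, a number 13.8 percentage points higher from compound 1 to compound 2 (beyond the scatter), the two results cannot be separated: the same change on two cores in this assay, a number 13.8 percentage points higher (beyond the scatter) from compound 1 to compound 2 and a number 3 percentage points higher (within the scatter) from compound 3 to compound 4, 10.8 percentage points apart, within the scatter of two such steps. The pair therefore does not show that the change carries over to the core of compound 3 with its full size, nor does it show that the core alters the outcome; with one step per core, both readings remain possible.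

The compounds shown leave open how a longer chain, such as phenethyl, would behave at this place on either core. They also leave open whether an amine or a carboxylic acid on the benzyl ring would give a step that reads clearly on both cores.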